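Swapping the aryl on the piperazine nitrogen for a pyridinylmethyl

This account rests on a few compounds, and the source may have more. Where it says the series, first, only, none or still open, it means among the compounds named here.

Measured compounds:
compound 1 `Nc1ccccc1NC(=O)c1ccc(CSC(=S)N2CCN(c3cccnc3)CC2)cc1`: 76.9%
compound 2 `COc1ccc(N2CCN(C(=S)SCc3ccc(C(=O)Nc4ccccc4N)cc3)CC2)cc1`: 22.9%
compound 3 `Nc1ccccc1NC(=O)c1ccc(CSC(=S)N2CCN(c3ccc(F)cc3)CC2)cc1`: 48.7%

In a functional assay on MGC-803 cells (Homo sapiens) for antiproliferative activity, read by CCK-8 assay, with a stated time of 72 h, tested at 8 uM (a lower number here means a weaker effect, a higher number a stronger effect of the compound at the concentration tested), compound 1 gives 76.9%, compound 2 gives 22.9% and compound 3 gives 48.7%. Compound 3 therefore stands second highest of the three: the step of a number 28.2 percentage points lower from compound 1 to compound 3 (beyond the scatter) is beyond the scatter, as is the step of a number 25.8 percentage points higher from compound 2 to compound 3 (beyond the scatter). The step of a number 54 percentage points lower from compound 1 to compound 2 (beyond the scatter) is the largest seen.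

Compound 4 `Nc1ccccc1NC(=O)c1ccc(CSC(=S)N2CCN(Cc3ccncc3)CC2)cc1` has not yet been measured. It differs from compound 3 in one place: (pyridin-4-yl)methyl in place of 4-fluorophenyl on an amine nitrogen in a ring. The measured steps that bear on this change are those at the same ring nitrogen, where moving from pyridin-3-yl to an aryl lowered the number, by a number 28.2 percentage points lower from compound 1 to compound 3 (beyond the scatter) and by a number 54 percentage points lower from compound 1 to compound 2 (beyond the scatter). Returning a pyridine ring, now carried on a methylene, is expected to move the number back up, though no measured pair covers the methylene itself, so the expected step is modest rather than large and its range is wide: a number 9.3 percentage points higher from compound 3 to compound 4 (within the scatter). Compound 4 is thus estimated at 58%, between 30% and 82%.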

Compound 4, a percentage reported as inhibition, at one concentration (the size of the read-out at that concentration, not a potency): 79.3%
For compound 4 the middle estimate is 21.3 percentage points below the measured one; low and high end bracket the measured number.
By their numbers in this assay, from the lowest: compound 2; then compound 3; then compounds 1 and 4 (each within the scatter of the next).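

In this assay, a pyridine ring carried on a methylene is well accepted on the amine nitrogen in the ring, with a number 30.6 percentage points higher from compound 3 to compound 4 (beyond the scatter) and a number 56.4 percentage points higher from compound 2 to compound 4 (beyond the scatter); the earlier compounds had shown a pyridine ring only when attached directly. Set against that directly attached pyridin-3-yl group, the result is a number 2.4 percentage points higher from compound 1 to compound 4 (within the scatter), so the methylene and the change of pyridine attachment together leave the number within the scatter. Among these four compounds, both groups with a nitrogen in the aromatic ring stand above the two with an aromatic ring of carbon only, with no compound going against this.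

The compounds shown leave open how much of the step rests on the ring nitrogen and how much on the methylene, which a plain benzyl group would separate, and whether a longer chain to the pyridine ring would hold the number. Nothing at hand bears on what lies behind these steps.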